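Sulfonyl pyridinone series: microsomal stability notes

The compounds below may be only part of what the source reports. "The series", "measured", "known", "first", "only" and "open" are said of these compounds alone.

Measured so far:
- compound 1, `CCCCc1[nH]c(=O)c(S(=O)(=O)c2ccc(-c3ccncc3C)cc2)c(O)c1-c1c(OC)cccc1OC`: 80%
- compound 2, `CCCCc1[nH]c(=O)c(S(=O)(=O)c2ccc(-c3ccc(F)nc3)cc2)c(O)c1-c1c(OC)cccc1OC`: "not determined" (no result reported)

In an ADME assay on microsomes from liver (Homo sapiens) for metabolic stability, using NADPH, with a stated time of 10 min (on this read-out lower numbers stand for a less stable compound and higher numbers for a more stable compound), compound 1 gives 80%. In this assay compound 2 gives "not determined" (no result reported), so compound 2 stands without a number on this read-out. Compound 3, `CCCCc1[nH]c(=O)c(S(=O)(=O)c2ccc(-n3ccccc3=O)cc2)c(O)c1-c1c(OC)cccc1OC`, differs from compound 2 by a group of 7 heavy atoms (5 carbon, 1 nitrogen, 1 oxygen; one six-membered aromatic ring with 1 hetero atom) in place of a group of 7 heavy atoms (5 carbon, 1 nitrogen, 1 fluorine; one six-membered aromatic ring with 1 hetero atom), on an aromatic carbon. Among the compounds with values here, with no measured step available, no direction beyond the scatter can be claimed for this change; the only bearing is compound 1 with 80%. For compound 3 the expected value in this assay is 75%, estimated range 50% to 95%.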

Compound 3, percent of the compound remaining: 100%
Compound 3: the middle estimate sits 25 percentage points below what was measured, outside the stated range (above it).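

In this assay, this position gives its first readable step, a number 20 percentage points higher from compound 1 to compound 3 (beyond the scatter) on the aromatic carbon para to a large group, so the read-out does respond to the group held there. Compound 2 has no number, so the step from it to compound 3 cannot be read. No measurement on hand accounts for the rise.

Still open, going by these compounds, is how an amine or a carboxylic acid on this aromatic carbon would read. Also open, on these data alone, is whether the rise holds with any other part of the shared core changed.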